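A few compounds are considered here, and "the series" means these few. Any claim that something is new, unique, unknown or untested is made for them only; others in the source may bear on it.

Working notes on the series in an ADME assay on HepG2 2.2.15 cells (Homo sapiens) for cytotoxicity; on this read-out lower numbers stand for higher toxicity in this test and higher numbers for lower toxicity in this test.

Of the compounds shown here, three carry a number so far. Compound 1 `O=c1c(CCO)c(-c2ccccc2Cl)c2cc(Cl)ccc2n1-c1ccccc1` gives 26000 nM in this assay. Compound 2 `O=CCc1c(-c2ccccc2Cl)c2cc(Cl)ccc2[nH]c1=O` gives 120000 nM in this assay. Compound 3 `O=C(OCCc1c(-c2ccccc2Cl)c2cc(Cl)ccc2[nH]c1=O)C1CCCCC1` gives 38000 nM in this assay, the second highest of the three numbers; its nearest neighbour is compound 1, within the scatter, and its furthest is compound 2, beyond the scatter. For the measured compounds named here, the only step between two measured compounds that differ in one place is a 3.2-fold lower number from compound 2 to compound 3 (0.50 log units; beyond the scatter).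

Compound 4 `O=C(/C=C/c1cccc(F)c1)OCCc1c(-c2ccccc2Cl)c2cc(Cl)ccc2[nH]c1=O` is not yet measured. It differs from compound 3 in one place: 2-(3-fluorophenyl)ethenyl in place of cyclohexyl on a carbonyl carbon. Going by the values given here, the ester is kept and only the group on the carbonyl carbon changes, so the one measured step, which exchanged a formyl for the whole ((cyclohexylcarbonyl)oxy)methyl group, bears on this change only loosely. Among the compounds with values here, nothing among the measured compounds tells how an ester of this type behaves in this assay. The expectation is therefore a step of about a 1.3-fold lower number from compound 3 to compound 4 (0.10 log units; within the scatter), not beyond the scatter. The estimate for compound 4 in this assay is 30000 nM, with a range from 12000 nM to 75000 nM.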

Compound 4, half-maximal cytotoxic concentration: > 1600000 nM
Compound 4: only a limit was reported; the forecaster's own chance of this, stated with the estimate: 10%; at least 53-fold (1.72 log units) between middle value and limit.
By their numbers in this assay, from the lowest: compounds 1 and 3 (each within the scatter of the next); then compound 2. At a limit, above all of these: compound 4.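

In this assay, exchanging cyclohexyl for 2-(3-fluorophenyl)ethenyl on the carbonyl carbon gives an at least 42-fold higher number from compound 3 to compound 4 (1.62 log units; beyond the scatter), so the group on this carbon can shift the read-out strongly even with the ester kept, which the earlier step could not show. Compound 4 gives > 1600000 nM, which is a limit of the assay and not a number. Only one compound in the series stands at this limit: the limit of > 1600000 nM in this assay, at which 1 of the 4 values shown sits.

The compounds shown do not separate the contributions of the double bond, the aromatic ring and the fluorine within the entering group. On these data alone, an unsubstituted 2-phenylethenyl group or a saturated 2-(3-fluorophenyl)ethyl chain on the same carbonyl carbon would address this, and how far the step extends past the limit remains open.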